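A few compounds are considered here, and "the series" means these few. Any claim that something is new, unique, unknown or untested is made for them only; others in the source may bear on it.

Working notes on the series. Within the data shown here, in a functional assay on T98G cells (Homo sapiens) for inhibition, read by MTT assay, with a stated time of 72 h (a higher number here means a weaker inhibitor, a lower number a stronger inhibitor), compound 1 `CC1(C)CC(NC(=S)Nc2cccc(C#N)c2)c2cc(Br)ccc2O1` gives 9000 nM, the second highest of the three numbers so far. Compound 3 `CC1(C)CC(NC(=S)Nc2cccc([N+](=O)[O-])c2)c2cc(Br)ccc2O1` gives 4000 nM, and compound 2 `CC1(C)CC(NC(=S)Nc2cccc(C#N)c2)c2cc(F)ccc2O1` gives 39000 nM.

Next is compound 4 `COc1ccccc1NC(=S)NC1CC(C)(C)Oc2ccc(Br)cc21`, which keeps the core of compound 1 and carries 2-methoxyphenyl in place of 3-cyanophenyl on an amide-type nitrogen.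

Among the measured compounds shown here, only one measured step changes this aryl group. Nitro in place of cyano gives a 2.3-fold lower number from compound 1 to compound 3 (0.35 log units; beyond the scatter), a modest change. The step of a 4.3-fold higher number from compound 1 to compound 2 (0.64 log units; beyond the scatter), fluoro in place of bromo, is larger but leaves the aryl group untouched, and compound 4 retains the bromo group, so it does not bear directly on this change. For the measured compounds named here, no measured compound carries 2-methoxyphenyl, and the data give no direction for its introduction.

With only the modest precedent from compound 3, no shift beyond the scatter is expected in this assay. The expected step is a 1.1-fold higher number from compound 1 to compound 4 (0.05 log units; within the scatter). The estimate for compound 4 is 10000 nM, with an expected range of 3500 nM to 30000 nM.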

Compound 4, half-maximal inhibitory concentration: 42000 nM
Beside the measured number, compound 4's estimate is 4.2-fold (0.62 log units) below it, and the stated range ends below it.
By their numbers in this assay, from the lowest: compound 3; then compound 1; then compounds 2 and 4 (each within the scatter of the next).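

In this assay, the aryl group on the amide-type nitrogen can move the number in either direction: 2-methoxyphenyl in place of 3-cyanophenyl gives (a 4.7-fold higher number from compound 1 to compound 4 (0.67 log units; beyond the scatter)), whereas nitro in place of cyano gave (a 2.3-fold lower number from compound 1 to compound 3 (0.35 log units; beyond the scatter)). The leaving and entering groups have the same count of heavy atoms and of hydrogen-bond acceptors, so those counts do not separate the two groups. No measurement shown accounts for this step.

The 2-methoxyphenyl and 3-cyanophenyl groups differ in both the substituent and its place on the ring, and the compounds shown do not separate those two changes. Also open, as far as these compounds go, is how an amino group or a carboxylic acid on this aryl group would affect the number, and whether the 2-methoxyphenyl step holds with fluoro in place of bromo.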